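A few compounds are considered here, and "the series" means these few. Any claim that something is new, unique, unknown or untested is made for them only; others in the source may bear on it.

Measured so far:
Compound 1 `O=C(NC[C@@H]1CCCO1)c1cn(Cc2ccc(-n3cccn3)cc2)c2cccnc12` – in an ADME assay on liver for metabolic stability, with Liver microsome (Homo sapiens) as the target, using microsomes (on this read-out higher numbers stand for fast clearance and lower numbers for slow clearance), compound 1 gives 133 mL/min/kg.
Compound 2 `Cc1cnc2c(C(=O)N[C@H]3CCOC[C@@H]3O)cn(Cc3ccc(-c4ccn(C)n4)cc3)c2c1` – in this assay compound 2 gives 2.5 mL/min/kg.

Of these two numbers, compound 1 stands highest; compound 2 gives a lower value, and the gap between them lies beyond the scatter. Compound 3 `O=C(N[C@H]1CC[C@H](CO)CC1)c1cn(Cc2ccc(-n3cccn3)cc2)c2cccnc12` keeps the core of compound 1 and differs in one place: 4-(hydroxymethyl)cyclohexyl in place of (oxolan-2-yl)methyl on an amide-type nitrogen. Within the data shown here, no measured pair isolates this change, so its effect is uncertain. For compound 3 a downward step in this assay is expected, of about a 2.2-fold lower number from compound 1 to compound 3 (0.35 log units; beyond the scatter). Compound 3 is therefore estimated at 60 mL/min/kg, within a range from 20 mL/min/kg to 150 mL/min/kg.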

Compound 3, clearance: 8.5 mL/min/kg
The estimate for compound 3 lay 7.1-fold (0.85 log units) above the measured number, and the stated range ends above it.
By their numbers in this assay, from the lowest: compound 2; then compound 3; then compound 1.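

The group on the amide-type nitrogen proves decisive in this assay: with the rest of compound 1 kept, 4-(hydroxymethyl)cyclohexyl in place of (oxolan-2-yl)methyl gives a 16-fold lower number from compound 1 to compound 3 (1.19 log units; beyond the scatter) on the same core. This is the only pair shown that isolates this place, and it shows that a change here alone can move clearance far beyond the scatter. No measurement shown here accounts for the step. Still open, from the compounds shown here alone, is whether the carbon-only ring or the hydroxymethyl carries this step. Plain cyclohexyl, or cyclohexyl bearing a carboxylic acid instead, would help separate the two.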